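Chain extension from compound 3 to compound 4

The source may report more compounds than this note shows. Statements on the series, on what has been measured and on what is new or still open speak of the compounds shown alone.

In a physicochemical assay for lipophilicity (a higher number here means a more lipophilic compound, a lower number a more polar compound), compound 1 (`CNC(=O)c1ccc(S(N)(=O)=O)cc1`) stands at -0.31 and compound 2 (`CCCNC(=O)c1ccc(S(N)(=O)=O)cc1`) at 0.51 in the series. Compound 3 (`CCCCNC(=O)c1ccc(S(N)(=O)=O)cc1`) is the highest of the three (1.05) and is the starting point here.

The next compound, compound 4 (`CCCCCCCNC(=O)c1ccc(S(N)(=O)=O)cc1`), carries propyl in place of hydrogen on a saturated chain carbon, four bonds along the chain from an amide-type nitrogen.

Among the compounds with values here, three measured steps bear on this change, and all lie beyond the scatter. The closest is a number 1.36 log units higher from compound 1 to compound 3 (beyond the scatter) with the same propyl entering, although on a saturated chain carbon bound to an amide-type nitrogen. The ethyl step a number 0.82 log units higher from compound 1 to compound 2 (beyond the scatter) and the methyl step a number 0.54 log units higher from compound 2 to compound 3 (beyond the scatter) are both smaller, so across these three steps the rise grows with the size of the entering group.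

A large rise of similar size to the propyl step is therefore expected, and the expected step is a number 1.45 log units higher from compound 3 to compound 4 (beyond the scatter) in this assay for now. For compound 4 the estimated value is 2.5 with an expected range from 2.1 to 3 as the working figure.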

Compound 4, partition coefficient: 2.57
Beside the measured number, compound 4's estimate is 0.07 log units below it; the range from low to high includes it.
By their numbers in this assay, from the lowest: compound 1; then compound 2; then compound 3; then compound 4.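

In this assay propyl four bonds along the chain from an amide-type nitrogen gives a number 1.52 log units higher from compound 3 to compound 4 (beyond the scatter) and so falls in the same large class as propyl on a saturated chain carbon bound to that nitrogen, which gave a number 1.36 log units higher from compound 1 to compound 3 (beyond the scatter) in the earlier series. Within the data shown here, the same chain read from the earlier compounds gives a number 2.06 log units higher from compound 2 to compound 4 (beyond the scatter) with butyl entering and a number 2.88 log units higher from compound 1 to compound 4 (beyond the scatter) with hexyl entering, so the number has not levelled off at compound 4. Every lengthening among the four compounds raises the number, and none goes against this; no supporting data explain the size of these steps.

Going by these compounds, whether the rise continues with a longer chain than that of compound 4 remains open. Also open, on these data alone, is how a branched chain, or an amine or carboxylic acid at the chain end, would compare at this position.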